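This account rests on a few compounds, and the source may have more. Where it says the series, first, only, none or still open, it means among the compounds named here.

Measured compounds:
compound 1 `O=C(Nc1ccc(-c2cnc3ccccn23)cc1)c1ccc([N+](=O)[O-])o1` — 0.412 h
compound 2 `COc1ccn2c(-c3ccc(NC(=O)c4ccc([N+](=O)[O-])o4)cc3)cnc2c1` — 0.472 h
compound 3 `COc1ccn2c(-c3ccc(NC(=O)c4ccc([N+](=O)[O-])o4)cc3F)cnc2c1` — 0.428 h

In an ADME assay on microsomes from liver (Homo sapiens) for metabolic stability (on this read-out lower numbers stand for a shorter-lived compound and higher numbers for a longer-lived compound), the three numbers sit close together: the step of a 1.1-fold higher number from compound 1 to compound 2 (0.06 log units; within the scatter) and the step of a 1.1-fold lower number from compound 2 to compound 3 (0.04 log units; within the scatter) are both within the scatter, and the values of compound 3 and compound 1 differ by even less, so none of the three can be told apart on this read-out. Compound 4 `COc1ccn2c(-c3ccc(NC(=O)c4ccc([N+](=O)[O-])o4)cc3C)cnc2c1` differs from compound 3 by methyl in place of fluoro on an aromatic carbon. Among the measured compounds shown here, the only measured step at this ring, a 1.1-fold lower number from compound 2 to compound 3 (0.04 log units; within the scatter), was within the scatter, and so was a 1.1-fold higher number from compound 1 to compound 2 (0.06 log units; within the scatter); nothing here points to a change beyond the scatter. For compound 4 the expected step is a 1.0-fold higher number from compound 3 to compound 4 (0.00 log units; within the scatter), meaning no real change. Compound 4 is therefore estimated at 0.43 h, within a range from 0.25 h to 0.75 h.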

Compound 4, half-life: 0.717 h
Compound 4: the middle estimate sits 1.7-fold (0.22 log units) below what was measured; low and high end bracket the measured number.
By their numbers in this assay, from the lowest: compounds 1, 3, 2 and 4 (each within the scatter of the next).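

In this assay, the methyl group on this aromatic carbon, ortho to a large group, gives a 1.7-fold higher number from compound 3 to compound 4 (0.22 log units; within the scatter) and a 1.5-fold higher number from compound 2 to compound 4 (0.18 log units; within the scatter). Among the compounds shown here, these are the largest steps so far, yet both remain within the scatter, so hydrogen, fluoro and methyl cannot be told apart here. No available evidence bears on these steps. On these data alone, it remains open whether an amine, a carboxylic acid or a longer chain on this carbon would shift the half-life beyond the scatter. As far as these compounds go, whether methyl would act alike on the core of compound 1 also stays open.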